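Methylpiperazine for piperidine on two hydroxyphenyl cores

The compounds below may be only part of what the source reports. "The series", "measured", "known", "first", "only" and "open" are said of these compounds alone.

Compound 1 `Cn1cnc2c(N3CCCCC3)nc(-c3ccccc3O)nc21` gives 50.5% in an assay on cells for displacement of a labelled ligand from adenosine receptor A1 (Homo sapiens), read by scintillation counting and radioligand binding, with a stated time of 60 min, tested at 10 uM; on this read-out lower numbers stand for less inhibition and higher numbers for more inhibition at the one concentration tested (going by the name of the read-out).
Compound 2 `CN1CCN(c2nc(-c3ccccc3O)nc3c2ncn3C)CC1` gives > 80% in this assay, a limit of the assay and not a number.
Compound 3 `Oc1ccc(-c2nc(N3CCCCC3)c3nc[nH]c3n2)cc1` gives > 80% in this assay, likewise a limit of the assay.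

Going by the values given here, the one measured step is a number at least 29.5 percentage points higher from compound 1 to compound 2 (beyond the scatter), the change being (4-methylpiperazin-1-yl in place of piperidin-1-yl on an aromatic carbon). The value of compound 2 is a limit, (the limit of > 80% in this assay, at which 2 of the 3 values shown sit), so the true size of that step is not known.

Compound 4 `CN1CCN(c2nc(-c3ccc(O)cc3)nc3[nH]cnc23)CC1` has not yet been measured. It differs from compound 3 by 4-methylpiperazin-1-yl in place of piperidin-1-yl on an aromatic carbon, the same kind of change as that from compound 1 to compound 2, although here the place is meta to a 4-hydroxyphenyl group rather than meta to a 2-hydroxyphenyl group. How the core of compound 3 differs from that of compound 1 is not broken down here.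

Compound 3 already sits at the limit, (the limit of > 80% in this assay, at which 2 of the 3 values shown sit), so compound 4 is expected to show a step that the limit leaves unreadable from compound 3 to compound 4, staying at or near that limit. Compound 4 is estimated at 88%, between 72% and 99%.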

Compound 4, a percentage reported as inhibition, at one concentration (the size of the read-out at that concentration, not a potency): > 80%
Compound 4 gave a limit, no number; the forecaster's own chance of this, stated with the estimate: 70%; the middle value does not contradict the limit.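

The step from compound 3 to compound 4 cannot be read, since both compounds stand at a limit of this assay and not at a number: the limit of > 80% in this assay, at which 3 of the 4 values shown sit.

The compounds shown leave open whether 4-methylpiperazin-1-yl in place of piperidin-1-yl raises the read-out on the core of compound 3, as it does from compound 1 to compound 2.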